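A few compounds are considered here, and "the series" means these few. Any claim that something is new, unique, unknown or untested is made for them only; others in the source may bear on it.

Two compounds built on a shared core have been run through a functional assay on PC-3 cells (Homo sapiens) for inhibition, read by sulforhodamine B assay, with a stated time of 48 h; on this read-out lower numbers stand for stronger inhibition of growth and higher numbers for weaker inhibition of growth. Compound 1 `COc1cc(-c2nn(-c3cccc(NC(=O)Nc4cc(C(F)(F)F)cc(C(F)(F)F)c4)c3)cc2-c2ccncc2)ccc1Cl` gives 250 nM in this assay, while compound 2 `COc1cc(-c2nn(-c3cccc(NC(=O)c4cccc(C(F)(F)F)c4)c3)cc2-c2ccncc2)ccc1Cl` gives 1230 nM, the higher of the two numbers and therefore the weaker inhibitor of growth, by a gap that lies beyond the usual scatter. Compound 3 `COc1cc(-c2nn(-c3cccc(NC(=O)Nc4ccc(Cl)c(Cl)c4)c3)cc2-c2ccncc2)ccc1Cl` has not yet been measured. It differs from compound 2 in one place: (3,4-dichlorophenyl)amino in place of 3-(trifluoromethyl)phenyl on a carbonyl carbon. The group that enters places an arylamino on the carbonyl carbon, the same arrangement that compound 1 carries, and compound 1 gives 250 nM. Because compound 1 gives 250 nM with that arrangement, a step toward stronger inhibition is expected, and its expected size is a 3.1-fold lower number from compound 2 to compound 3 (0.49 log units; beyond the scatter). For compound 3 the number in this assay is estimated at 400 nM, with a likely range from 150 nM to 1200 nM.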

Compound 3, concentration for 50% growth inhibition: 554 nM
Compound 3: the middle estimate sits 1.4-fold (0.14 log units) below what was measured, and the stated range covers the measured number.
By their numbers in this assay, from the lowest: compound 1; then compound 3; then compound 2.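

In this assay, placing (3,4-dichlorophenyl)amino in place of 3-(trifluoromethyl)phenyl on the carbonyl carbon gives a 2.2-fold lower number from compound 2 to compound 3 (0.35 log units; beyond the scatter) and is the first step shown at this position, so in this one pair the arylamino group goes with stronger inhibition of growth. The change alters two things at once, adding a nitrogen with its hydrogen-bond donor and replacing the trifluoromethyl group on the ring with two chlorines, so the step cannot be divided between them. Nothing measured here explains the step.

A (3-(trifluoromethyl)phenyl)amino group on this carbonyl carbon, keeping the ring of compound 2 and adding only the nitrogen, would separate those two changes. A small group such as methylamino in the same place would test whether the aromatic ring matters at all.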